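The source may hold more compounds than are shown below. What is called first, only, known or untested is meant among the compounds shown, and "the series" means these compounds.

Of the compounds shown here, three have been measured for lipophilicity. Compound 1 `CC(C)=CCC/C(C)=C/CC/C(C)=C\Cn1cc(-c2ccccc2)nn1` gives 6.95 in a physicochemical assay for lipophilicity, measured as octanol-water partition (a higher number here means a more lipophilic compound, a lower number a more polar compound), while compound 2 `CC(C)=CCC/C(C)=C\Cn1cc(-c2ccccc2)nn1` gives 4.91 in this assay. These two differ in one place, (3-methylbut-2-en-1-yl in place of hydrogen on a saturated chain carbon bound to a double-bonded chain carbon), and the step is a number 2.04 log units higher from compound 2 to compound 1 (beyond the scatter). Compound 3 `CCCCCCCCc1cn(CC=C(C)C)nn1` gives 4.92 in this assay; how its core differs from the core of compound 2 is not broken down here, and their two values lie within the scatter of each other.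

Compound 4 `CCCCCCCCc1cn(C/C=C(\C)CCC=C(C)C)nn1` has not yet been measured. Going by the values given here, it differs from compound 3 by 3-methylbut-2-en-1-yl in place of hydrogen on a saturated chain carbon bound to a double-bonded chain carbon, the same change, at the same kind of place, as the one seen between compound 2 and compound 1. Because that earlier step was a number 2.04 log units higher from compound 2 to compound 1 (beyond the scatter), a step of similar size is expected here, namely a number 1.98 log units higher from compound 3 to compound 4 (beyond the scatter). Compound 4 is therefore estimated at 6.9, with a plausible range from 6.4 to 7.4.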

Compound 4, partition coefficient: 6.92
For compound 4 the middle estimate is 0.02 log units below the measured one, and the stated range covers the measured number.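

In this assay the change from hydrogen to 3-methylbut-2-en-1-yl gives a number 2.00 log units higher from compound 3 to compound 4 (beyond the scatter) on one core and a number 2.04 log units higher from compound 2 to compound 1 (beyond the scatter) on the other, so in these two pairs the step carries over from one core to the other with the same direction and a similar size. This rests on two pairs alone and shows nothing about other cores, other places on the chain or other assays. No measurement shown accounts for the size of the step.

The compounds shown leave open whether the step holds on a core that carries an amine or a carboxylic acid. They also leave open what a further 3-methylbut-2-en-1-yl on the longer chain would give.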